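The compounds below may be only part of what the source reports. "The series", "measured", "known", "first", "only" and "open" are said of these compounds alone.

Compound 1 `COc1ccc(-c2nc(N=C(N)N)sc2-c2ccc(OC)cc2)cc1` carries a guanidine-type group on its shared core, and in a functional assay with Oryctolagus cuniculus as the target (a lower number here means a stronger inhibitor, a higher number a weaker inhibitor), compound 1 gives 31000 nM, the highest of the two numbers recorded here. Compound 3 `C/N=C(/NC)Nc1nc(-c2ccc(OC)cc2)c(-c2ccc(OC)cc2)s1` gives 970 nM in this assay, and the step of a 32-fold lower number from compound 1 to compound 3 (1.50 log units; beyond the scatter) is large. Compound 2 `CC/N=C(/N)Nc1nc(-c2ccc(OC)cc2)c(-c2ccc(OC)cc2)s1` is known in this assay only as a limit, > 100 nM. Because of that limit of > 100 nM in this assay, at which 1 of the 3 values shown sits, the step that the limit leaves unreadable from compound 1 to compound 2 cannot be read. Compound 4 `COc1ccc(-c2nc(CN(C)C)sc2-c2ccc(OC)cc2)cc1` has not yet been measured; it differs from compound 1 in one place: a group of 4 heavy atoms (3 carbon, 1 nitrogen; no ring) in place of a group of 4 heavy atoms (1 carbon, 3 nitrogen; no ring), on an aromatic carbon. Among the compounds with values here, neither measured step replaces the leaving group with anything other than a larger relative of itself, so none bears directly on this change; the one readable step away from compound 1 was large and toward a lower number. The expectation is therefore a moderate step toward a lower number, a 3.1-fold lower number from compound 1 to compound 4 (0.49 log units; beyond the scatter), with wide uncertainty. For compound 4 in this assay the estimate is 10000 nM, within a range from 1500 nM to 60000 nM.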

Compound 4, half-maximal inhibitory concentration: 96 nM
Compound 4: the middle estimate sits 100-fold (2.02 log units) above what was measured, and the stated range ends above it.
By their numbers in this assay, from the lowest: compound 4; then compound 3; then compound 1.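

In this assay, replacing the guanidine-type group on the aromatic carbon with (dimethylamino)methyl gives the largest readable step in the series, a 320-fold lower number from compound 1 to compound 4 (2.51 log units; beyond the scatter). Within the data shown here, until now, the only readable change at this position was to a larger relative of the leaving group, but a group with no hydrogen-bond donors goes further still, with a 10-fold lower number from compound 3 to compound 4 (1.00 log units; beyond the scatter). The remaining step, an at least 1.0-fold lower number from compound 2 to compound 4 (0.01 log units; that floor lies within the scatter), rests on a limit and does not settle the order of those two compounds: the limit of > 100 nM in this assay, at which 1 of the 4 values shown sits.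

On these data alone, what a plain methyl or a hydroxymethyl group would give on this carbon remains open. So does the effect of a longer chain carrying the same dimethylamino group, or of a cyclic amine such as morpholine in its place.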